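Swapping nitro for hydrogen on the aromatic ring

A few compounds are considered here, and "the series" means these few. Any claim that something is new, unique, unknown or untested is made for them only; others in the source may bear on it.

Measured compounds:
compound 1 `CC(C)[C@H]1CC[C@@]2(CO2)[C@H]2C(=O)OCC(C(=O)OCc3ccc(-c4ccc([N+](=O)[O-])cc4)o3)=C[C@H]12`: 3600 nM
compound 2 `C=C(C(=O)O)C1OC(=O)[C@H]2[C@H]1[C@@H](C(C)C)CC[C@@]2(O)CI`: > 10000 nM

Going by the values given here, compound 1 `CC(C)[C@H]1CC[C@@]2(CO2)[C@H]2C(=O)OCC(C(=O)OCc3ccc(-c4ccc([N+](=O)[O-])cc4)o3)=C[C@H]12` is the only compound here with a number to its name. In a functional assay on WM 266-4 cells (Homo sapiens) for inhibition, with a stated time of 72 h (a higher number here means a weaker inhibitor, a lower number a stronger inhibitor), compound 1 gives 3600 nM. Compound 2 `C=C(C(=O)O)C1OC(=O)[C@H]2[C@H]1[C@@H](C(C)C)CC[C@@]2(O)CI` offers no number at all: in this assay compound 2 gives > 10000 nM, which is a limit of the assay and not a measured value, namely (the limit of > 10000 nM in this assay, at which 1 of the 2 values shown sits). Among the compounds with values here, the two compounds share no single point of difference, so no measured step exists to lean on.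

Compound 3 `CC(C)[C@H]1CC[C@@]2(CO2)[C@H]2C(=O)OCC(C(=O)OCc3ccc(-c4ccccc4)o3)=C[C@H]12` differs from compound 1 by hydrogen in place of nitro on an aromatic carbon. Within the data shown here, with no comparable step in hand, the step from compound 1 to compound 3 is expected to be small, most likely no larger than the usual scatter, and if anything a slight loss of potency is expected, a 1.4-fold higher number from compound 1 to compound 3 (0.14 log units; within the scatter). Compound 3 is therefore estimated to give 5000 nM in this assay, within a range from 1500 nM to 15000 nM.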

Compound 3, half-maximal inhibitory concentration: 960 nM
The estimate for compound 3 lay 5.2-fold (0.72 log units) above the measured number; the whole stated range lies above it.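

In this assay the change from 4-nitrophenyl to phenyl gives a 3.8-fold lower number from compound 1 to compound 3 (0.57 log units; beyond the scatter), a modest step but one beyond the scatter. It is the first comparison in one place among the compounds shown, and it shows that the group carried at this aromatic carbon affects the result and that nitro is not required for activity on the core of compound 1. Nothing measured here bears on why the step runs in this direction.

The compounds shown leave open whether other groups at this place, such as an amine, a methoxy group or a carboxylic acid, would match compound 3 or fall back towards compound 1. Going by these compounds alone, with only one step at one position, they also leave open whether the same change would have a similar effect on a different core.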